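The source may report more compounds than this note shows. Statements on the series, on what has been measured and on what is new or still open speak of the compounds shown alone.

Three compounds share one core and differ in the groups attached to it. In a functional assay on K562 cells (Homo sapiens) for antiproliferative activity, read by MTT assay, with a stated time of 48 h (a higher number here means a weaker inhibitor, a lower number a stronger inhibitor), compound 1 `COc1ccc(-c2ccc3c(c2)C(=O)C(=O)N3Cc2cccc(Cl)c2)cc1` gives 200 nM, and compound 2 `COc1ccc(-c2ccc3c(c2)C(=O)C(=O)N3Cc2ccc(OC)c(OC)c2)cc1` gives 60 nM. Between them the change is a 3.3-fold lower number from compound 1 to compound 2 (0.52 log units; beyond the scatter). Compound 3 `COc1ccc(CN2C(=O)C(=O)c3cc(-c4ccc(C(C)(C)C)cc4)ccc32)cc1` gives 2250 nM, the highest of the three numbers, beyond the scatter from both others. Compound 4 `COc1ccc(CN2C(=O)C(=O)c3cc(-c4ccc5ccccc5c4)ccc32)cc1` differs from compound 3 in one place: naphthalen-2-yl in place of 4-(tert-butyl)phenyl on an aromatic carbon. Among the compounds with values here, no measured pair alters this group; the only measured step, from compound 1 to compound 2, changes a different part of the molecule, so it offers no guidance here. With nothing to point either way, no step beyond the scatter is expected, and the estimate for compound 4 is 1500 nM, within a range from 300 nM to 7000 nM. That expectation corresponds to a 1.5-fold lower number from compound 3 to compound 4 (0.18 log units; within the scatter).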

Compound 4, half-maximal inhibitory concentration: 340 nM
Estimate against measurement, compound 4: 4.4-fold (0.64 log units) above; measured number inside the range.
By their numbers in this assay, from the lowest: compound 2; then compounds 1 and 4 (each within the scatter of the next); then compound 3.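

Changing the group on this aromatic carbon from 4-(tert-butyl)phenyl to naphthalen-2-yl gives a 6.6-fold lower number from compound 3 to compound 4 (0.82 log units; beyond the scatter) in this assay with the heavy-atom count unchanged. Within the data shown here, this is the first sign that this position responds to a change, since the earlier step altered a different part of the molecule. No measurement here accounts for the difference. From the compounds shown here alone, it remains open how a phenyl carrying an amine or a carboxylic acid would behave at this position. Also open, going by these compounds, is whether naphthalen-2-yl gives a similar step alongside the 3,4-dimethoxyphenyl group of compound 2.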